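The source may hold more compounds than are shown below. What is called first, only, known or untested is meant among the compounds shown, and "the series" means these compounds.

Compound 1 `Cc1cc(C#N)cc(C)c1Oc1nc(NC2CCC(NC(=O)c3ccccc3)CC2)nc2ccsc12`: 3930 nM
Compound 2 `Cc1cc(C#N)cc(C)c1Oc1nc(NC2CCC(NC(=O)c3ccc(Br)cc3)CC2)nc2ccsc12`: 2850 nM

Both were tested in an ADME assay on MT4 cells (Homo sapiens) for cytotoxicity, read by MTT assay, with a stated time of 5 days; a higher number here means that more compound is tolerated, a lower number that less compound is tolerated. Going by the values given here, compound 2 and compound 1 sit within the scatter of each other: the single measured step, a 1.4-fold lower number from compound 1 to compound 2 (0.14 log units; within the scatter), is too small to separate them, so compound 2 cannot be called better or worse tolerated than compound 1.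

Compound 3 `Cc1cc(C#N)cc(C)c1Oc1nc(NC2CCC(NC(=O)c3cccc(C(F)(F)F)c3)CC2)nc2ccsc12` differs from compound 2 in one place: 3-(trifluoromethyl)phenyl in place of 4-bromophenyl on a carbonyl carbon. Among the compounds with values here, the only measured step that bears on this, a 1.4-fold lower number from compound 1 to compound 2 (0.14 log units; within the scatter), also swapped a group on the aromatic ring attached to the carbonyl carbon and stayed within the scatter. Within the data shown here, no measured step covers a trifluoromethyl group or this arrangement, so the expectation rests on that one step alone. The step from compound 2 to compound 3 is therefore expected to be a 1.0-fold lower number from compound 2 to compound 3 (0.01 log units; within the scatter), nothing beyond the scatter. Compound 3 is estimated at 2800 nM, within a range from 1200 nM to 6500 nM.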

Compound 3, half-maximal cytotoxic concentration: 3240 nM
Compound 3: the middle estimate sits 1.2-fold (0.06 log units) below what was measured; the range from low to high includes it.
By their numbers in this assay, from the lowest: compounds 2, 3 and 1 (each within the scatter of the next).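

The exchange of 4-bromophenyl for 3-(trifluoromethyl)phenyl on the carbonyl carbon gives a 1.1-fold higher number from compound 2 to compound 3 (0.06 log units; within the scatter), and adding trifluoromethyl to the unsubstituted ring gives a 1.2-fold lower number from compound 1 to compound 3 (0.08 log units; within the scatter). Each of the three compounds now lies within the scatter of the next in this assay, so the unsubstituted ring, the 4-bromophenyl and the 3-(trifluoromethyl)phenyl cannot be told apart there. Compared with the earlier pair, this extends the flat result from a single bromine to a group of more heavy atoms, carrying fluorine.

As far as these compounds go, whether this flat result would hold for a ring carrying an amine or a carboxylic acid, or for a longer chain in place of the ring, remains open. Nothing at hand helps to explain these numbers.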